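The source may report more compounds than this note shows. Statements on the series, on what has been measured and on what is new or still open speak of the compounds shown alone.

Compound 2 `CC(C)Oc1ccc(Cc2ccc(NC3=NCCN3)cc2)cc1` holds the highest of the three numbers in a functional assay on SH-SY5Y cells (Homo sapiens) for antagonist activity, read by cAMP accumulation (on this read-out lower numbers stand for lower potency and higher numbers for higher potency (the scale is a negative logarithm)), where compound 2 gives 8.8. Its nearest neighbour is compound 3 `c1cc(NC2=NCCN2)ccc1Cc1ccc(OC2CCCCC2)cc1`, which in this assay gives 8.6; the step of a number 0.20 log units lower from compound 2 to compound 3 (within the scatter) lies within the scatter and is not read as a change. Compound 1 `CCOc1ccc(Cc2ccc(NC3=NCCN3)cc2)cc1` stands furthest away, giving 8.2 in this assay; the step of a number 0.60 log units higher from compound 1 to compound 2 (beyond the scatter) and the step of a number 0.40 log units higher from compound 1 to compound 3 (beyond the scatter) both lie beyond the scatter.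

The unmeasured compound 4 `c1cc(NC2=NCCN2)ccc1Cc1ccc(OC2CCOCC2)cc1` differs from compound 2 by oxan-4-yl in place of isopropyl on an oxygen on an aromatic ring. The measured steps that bear on this are the two that exchange the group on the same oxygen, a number 0.40 log units higher from compound 1 to compound 3 (beyond the scatter) and a number 0.20 log units lower from compound 2 to compound 3 (within the scatter): a six-membered non-aromatic ring on that oxygen gave a number close to the isopropyl case and somewhat above the ethyl case. Within the data shown here, no measured compound carries a ring with a hetero atom on that oxygen, so what the oxygen of the oxan-4-yl ring adds is unknown. Compound 4 is therefore expected to land near compound 2 or a little lower, with a step of a number 0.30 log units lower from compound 2 to compound 4 (within the scatter) of about the size seen for compound 3. The estimate for compound 4 in this assay is 8.5, with a range from 7.9 to 9.1.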

Compound 4, negative logarithm of the antagonist equilibrium constant: 8.4
Compound 4: middle estimate off by 0.10 log units, on the high side; the measured number falls inside the stated range.
By their numbers in this assay, from the lowest: compounds 1, 4, 3 and 2 (each within the scatter of the next, the first and the last beyond it).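

In this assay, among these compounds, oxan-4-yl is the first ring on the oxygen on an aromatic ring to separate from isopropyl (a number 0.40 log units lower from compound 2 to compound 4 (beyond the scatter)), which cyclohexyl did not do (a number 0.20 log units lower from compound 2 to compound 3 (within the scatter)). Yet oxan-4-yl cannot be told apart from cyclohexyl (a number 0.20 log units lower from compound 3 to compound 4 (within the scatter)) or from ethyl (a number 0.20 log units higher from compound 1 to compound 4 (within the scatter)), even though cyclohexyl stands clear of ethyl (a number 0.40 log units higher from compound 1 to compound 3 (beyond the scatter)), so compound 4 overlaps with both of those neighbours and the ring oxygen shows no separate effect of its own. Nothing available here accounts for the step away from isopropyl.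

Going by these compounds, it remains open whether a piperidin-4-yl ring with its amine nitrogen, a cyclopentyl ring or a longer chain such as n-butyl on the same oxygen would stay with isopropyl or fall back towards ethyl. Also open, on these data alone, is whether a carboxylic acid carried on that group, or any change elsewhere on the shared core, would keep these groups in the same order.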